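Acylamino thiadiazoles: phenoxymethyl in place of phenyl

This account rests on a few compounds, and the source may have more. Where it says the series, first, only, none or still open, it means among the compounds named here.

Compound 3 `O=C(Nc1nnc(-c2ccc(O)c(O)c2)s1)c1ccccc1` gives 13000 nM in a functional assay on A549 cells (Homo sapiens) for cytotoxicity, read by MTT assay, with a stated time of 72 h; a lower number here means a stronger inhibitor, a higher number a weaker inhibitor. Among the three measured compounds it stands second highest; its nearest neighbour is compound 2 `O=C(COc1ccccc1)Nc1nnc(-c2cccc(O)c2O)s1`, which gives 10500 nM, a gap within the scatter, and its furthest is compound 1 `CC(=O)Nc1nnc(-c2ccc(O)c(O)c2)s1`, which gives 133000 nM, a gap beyond the scatter.

Compound 4 `O=C(COc1ccccc1)Nc1nnc(-c2ccc(O)c(O)c2)s1` is the next member, differing from compound 3 in one place: phenoxymethyl in place of phenyl on a carbonyl carbon.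

Among the compounds with values here, the only measured step of one change is a 10-fold lower number from compound 1 to compound 3 (1.01 log units; beyond the scatter), which concerns the same carbonyl carbon but a different pair of groups, so it sets the scale of what this position can do rather than the direction of the present change. Compound 2 carries the phenoxymethyl group on a core with a different hydroxyl arrangement and its value sits within the scatter of compound 3; no step between compound 2 and compound 4 is shown. On these data the move to compound 4 is expected to give a step of a 1.2-fold lower number from compound 3 to compound 4 (0.07 log units; within the scatter), within the scatter in either direction. For compound 4 the estimate in this assay is therefore 11000 nM, with a range from 5000 nM to 25000 nM.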

Compound 4, half-maximal inhibitory concentration: 21200 nM
Compound 4: the middle estimate sits 1.9-fold (0.28 log units) below what was measured, and the stated range covers the measured number.
By their numbers in this assay, from the lowest: compounds 2, 3 and 4 (each within the scatter of the next, the first and the last beyond it); then compound 1.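

In this assay, phenoxymethyl in place of phenyl on the carbonyl carbon gives a 1.6-fold higher number from compound 3 to compound 4 (0.21 log units; within the scatter), so this change does not separate the two groups on the shared core. Phenoxymethyl also keeps much of the difference from methyl seen with phenyl: a 6.3-fold lower number from compound 1 to compound 4 (0.80 log units; beyond the scatter), against a 10-fold lower number from compound 1 to compound 3 (1.01 log units; beyond the scatter). The hydroxyl arrangement can now be read apart from the acyl group, and 3,4-dihydroxyphenyl in place of 2,3-dihydroxyphenyl gives a 2.0-fold higher number from compound 2 to compound 4 (0.31 log units; beyond the scatter), a modest step just beyond the scatter.

Open, going by these compounds, is whether an aminomethyl group, a carboxylic acid or a longer chain such as phenoxypropyl on the carbonyl carbon would stay level with phenyl and phenoxymethyl. Nothing available here accounts for any of these steps.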